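The source may report more compounds than this note shows. Statements on the series, on what has been measured and on what is new or still open speak of the compounds shown alone.

Measured so far:
compound 1 `CC1(C)C2CC[C@@]1(CS(=O)(=O)NC(=O)c1ccc(N3CCN(Cc4ccccc4-c4ccc(Cl)cc4)CC3)cc1)C(=O)C2`: 1470 nM
compound 2 `CC1(C)[C@@]2(C)CC[C@H](CS(=O)(=O)NC(=O)c3ccc(N4CCN(Cc5ccccc5-c5ccc(Cl)cc5)CC4)cc3)[C@]1(C)C2`: 560 nM
compound 3 `CC1(C)C2CC[C@]1(CS(=O)(=O)NC(=O)c1ccc(N3CCN(Cc4ccccc4-c4ccc(Cl)cc4)CC3)cc1)C(=O)C2`: 1020 nM

In an assay on isolated protein for inhibition of Apoptosis regulator Bcl-2/Bcl-2 homologous antagonist/killer (Homo sapiens), read by surface plasmon resonance, with a stated time of 1 h (on this read-out higher numbers stand for an effect only at larger amounts of compound and lower numbers for an effect already at smaller amounts), compound 3 stands second highest of the three, close to compound 1 and somewhat apart from compound 2, both gaps within the scatter. Compound 1 and compound 3 share every atom and bond and differ only in how one stereocentre is drawn (the fact that one of compounds 1 and 3 is drawn with a defined configuration and the other without, at the place where they differ), so a 1.4-fold lower number from compound 1 to compound 3 (0.16 log units; within the scatter) is read as no real change. Compound 4 `CC1(C)[C@]2(C)CC[C@@H](CS(=O)(=O)NC(=O)c3ccc(N4CCN(Cc5ccccc5-c5ccc(Cl)cc5)CC4)cc3)[C@@]1(C)C2` carries the change (a group of 11 heavy atoms (11 carbon; one four-membered non-aromatic ring of carbon only, one six-membered non-aromatic ring of carbon only) in place of a group of 10 heavy atoms (9 carbon, 1 oxygen; 2 five-membered non-aromatic rings of carbon only), on a saturated chain carbon bound to a sulfonyl sulfur). The same exchange appears twice already: a 2.6-fold lower number from compound 1 to compound 2 (0.42 log units; beyond the scatter), a modest gain, and its reverse 1.8-fold higher number from compound 2 to compound 3 (0.26 log units; within the scatter), within the scatter. A small drop in the number is therefore expected for compound 4, about a 1.7-fold lower number from compound 3 to compound 4 (0.23 log units; within the scatter), giving an estimated 600 nM in this assay, most likely between 250 nM and 1500 nM.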

Compound 4, half-maximal effective concentration: 420 nM
Estimate against measurement, compound 4: 1.4-fold (0.15 log units) above; low and high end bracket the measured number.
By their numbers in this assay, from the lowest: compounds 4, 2, 3 and 1 (each within the scatter of the next, the first and the last beyond it).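

Compound 4 carries the 11-carbon group, and the exchange now lies beyond the scatter against both compounds with the oxygen-bearing group (a 2.4-fold lower number from compound 3 to compound 4 (0.39 log units; beyond the scatter); a 3.5-fold lower number from compound 1 to compound 4 (0.54 log units; beyond the scatter)). Compound 2 goes against this pattern, since its gap to compound 3 stays within the scatter. Inverting every stereocentre gives no real change (a 1.3-fold lower number from compound 2 to compound 4 (0.12 log units; within the scatter)), and this pair differs in one way only: the fact that compounds 2 and 4 differ only in the configuration as drawn.

As far as these compounds go, the ring framework and the oxygen change together in each exchange, so their separate contributions stay open. Also open, from the compounds shown here alone, is how a carboxylic acid or a cyclohexyl group would read at this place.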